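This account rests on a few compounds, and the source may have more. Where it says the series, first, only, none or still open, it means among the compounds named here.

Working notes on the series in an ADME assay on microsomes from liver (Rattus norvegicus) for metabolic stability, with a stated time of 60 min, tested at 1 uM; a lower number here means that less of the compound is left, a higher number that more of the compound is left. Compound 3 `COc1cc(-c2cnn3cc(OC)c(C(C)(C)O)nc23)ccn1` gives 92% and stands highest of the three measured compounds; compound 2 `COc1cn2ncc(-c3ccnc(OC(C)(C)C)c3)c2nc1-c1cnn(C)c1` gives 61%, and compound 1 `COc1cc(-c2cnn3cc(OC)c(C(C)C)nc23)ccn1` gives 14%, both beyond the scatter below compound 3. Among the measured compounds shown here, the one step measured is a number 78 percentage points higher from compound 1 to compound 3 (beyond the scatter). Compound 4 `COc1cc(-c2cnn3cc(OC)c([C@@H]4COC(C)(C)C4)nc23)ccn1` is not yet measured; it differs from compound 3 by a group of 7 heavy atoms (6 carbon, 1 oxygen; one five-membered non-aromatic ring with 1 hetero atom) in place of a group of 4 heavy atoms (3 carbon, 1 oxygen; no ring), on an aromatic carbon. That step bears on the measured one because a number 78 percentage points higher from compound 1 to compound 3 (beyond the scatter) was tied to the hydroxy entering, and in compound 4 the hydroxy leaves while a ring ether enters, so a downward step of moderate to large size is expected, short of a full return to compound 1. The expected step for compound 4 is a number 47 percentage points lower from compound 3 to compound 4 (beyond the scatter), giving an estimate of 45% with a range of 15% to 80%.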

Compound 4, percent of the compound remaining: 30%
Estimate against measurement, compound 4: 15 percentage points above; the measured number falls inside the stated range.
By their numbers in this assay, from the lowest: compound 1; then compound 4; then compound 2; then compound 3.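

In this assay, the group with the five-membered non-aromatic ring keeps only a modest gain over the parent chain, a number 16 percentage points higher from compound 1 to compound 4 (beyond the scatter), while losing far more against the hydroxy group, a number 62 percentage points lower from compound 3 to compound 4 (beyond the scatter). An oxygen in the group at this aromatic carbon is therefore not enough on its own: the entering group keeps 1 hydrogen-bond acceptor but has 0 hydrogen-bond donors, and it stands well below compound 3. No measurement at hand explains this result. From the compounds shown here alone, the ring and the loss of the hydroxy arrive together in this step, so their shares stay unseparated, and an amine or a carboxylic acid on this carbon remains open.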